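Amide-tail variation on a shared core: working notes

A few compounds are considered here, and "the series" means these few. Any claim that something is new, unique, unknown or untested is made for them only; others in the source may bear on it.

Measured so far:
Compound 1 `CC1=C(C(C)C(=O)N(C)CCN(C)C)c2cc(F)ccc2/C1=C\c1ccc([S+](C)[O-])cc1` — in a functional assay on MDA-MB-231 cells (Homo sapiens) for inhibition, read by CellTiter-Glo, with a stated time of 96 h (on this read-out higher numbers stand for lower toxicity in this test and lower numbers for higher toxicity in this test), compound 1 reaches only the assay limit > 50000 nM.
Compound 2 `CC1=C(C(C)C(=O)N2CCN(c3ccncc3)CC2)c2cc(F)ccc2/C1=C\c1ccc([S+](C)[O-])cc1` — compound 2 gives 19600 nM.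
Compound 3 `CC1=C(C(C)C(=O)N(C)CCN(C)C(=O)[C@@H](N)C(C)C)c2cc(F)ccc2/C1=C\c1ccc([S+](C)[O-])cc1` — compound 3 gives 47600 nM.

Compound 3 holds the highest of the two actual numbers; compound 2 sits clearly lower. Compound 1 is a limit only (the limit of > 50000 nM in this assay, at which 1 of the 3 values shown sits).

Compound 4 `CC1=C(C(C)C(=O)N(C)CCN(C)C(=O)[C@@H]2CCCN2)c2cc(F)ccc2/C1=C\c1ccc([S+](C)[O-])cc1` differs from compound 3 by pyrrolidin-2-yl in place of 1-amino-2-methylpropyl on a carbonyl carbon. The step that bears on this position is an at least 1.0-fold lower number from compound 1 to compound 3 (0.02 log units; that floor lies within the scatter), which stayed within the scatter; the other step, an at least 2.5-fold lower number from compound 1 to compound 2 (0.40 log units; beyond the scatter), changed a different part of the amide and was at least modest. Swapping one five-heavy-atom amine-bearing group for another of matching count is expected to give a 1.2-fold lower number from compound 3 to compound 4 (0.08 log units; within the scatter), i.e. nothing beyond the scatter. Compound 4 is therefore estimated at 40000 nM, with a range of 14000 nM to 110000 nM; a limit rather than a number is possible.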

Compound 4, half-maximal cytotoxic concentration: > 50000 nM
Compound 4 ended at the assay's limit (the forecaster's own chance of this, stated with the estimate: 30%); middle value at least 1.2-fold (0.09 log units) away from the limit.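

In this assay, pyrrolidin-2-yl in place of 1-amino-2-methylpropyl on this carbonyl carbon gives an at least 1.0-fold higher number from compound 3 to compound 4 (0.02 log units; that floor lies within the scatter), so the ring form cannot be told apart from the open-chain group. The step from compound 1 to compound 4 has a limit at both ends and cannot be read. The top of the read-out restricts what this position can show: the limit of > 50000 nM in this assay, at which 2 of the 4 values shown sit.

From the compounds shown here alone, whether a carboxylic acid or a longer alkyl amine in place of pyrrolidin-2-yl on this carbonyl carbon would give a number clearly below that limit stays open.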